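Returning the Amino Link on the Carbonyl Carbon

The source may report more compounds than this note shows. Statements on the series, on what has been measured and on what is new or still open speak of the compounds shown alone.

Compound 1, `COc1cc(-c2nn(-c3cccc(NC(=O)Nc4cccc(C(F)(F)F)c4)c3)cc2-c2ccncc2)ccc1Cl`: 1120 nM
Compound 2, `COc1cc(-c2nn(-c3cccc(NC(=O)c4ccc(Cl)c(C(F)(F)F)c4)c3)cc2-c2ccncc2)ccc1Cl`: 3080 nM

Both numbers come from a functional assay on SK-MEL-28 cells (Homo sapiens) for inhibition, read by sulforhodamine B assay, with a stated time of 48 h; on this read-out higher numbers stand for weaker inhibition of growth and lower numbers for stronger inhibition of growth. Among the compounds with values here, only one step has been measured, a 2.8-fold higher number from compound 1 to compound 2 (0.44 log units; beyond the scatter); the compound that step ends on, compound 2, holds the highest of the two numbers, and nothing else measured stands close to it.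

Compound 3 is `COc1cc(-c2nn(-c3cccc(NC(=O)Nc4ccc(Cl)c(C(F)(F)F)c4)c3)cc2-c2ccncc2)ccc1Cl`. Its change from compound 2 is (4-chloro-3-(trifluoromethyl)phenyl)amino in place of 4-chloro-3-(trifluoromethyl)phenyl on a carbonyl carbon. Within the data shown here, this is the mirror image of the one measured step: the amino link that was removed going from compound 1 to compound 2 is put back, while the chlorine-bearing ring is kept. Since that removal gave a modest rise in the number, reversing it is expected to give a modest fall of similar size, so a 2.8-fold lower number from compound 2 to compound 3 (0.45 log units; beyond the scatter) is the expected step. Compound 3 is therefore expected to give about 1100 nM in this assay, with a likely range from 450 nM to 2700 nM.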

Compound 3, concentration for 50% growth inhibition: 1200 nM
Estimate against measurement, compound 3: 1.1-fold (0.04 log units) below, within the range that was stated.
By their numbers in this assay, from the lowest: compounds 1 and 3 (each within the scatter of the next); then compound 2.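

In this assay, within the data shown here, the one earlier step swapped the link on the carbonyl carbon and added a chloro on the ring at the same time, and compound 3 separates these two changes. With the 4-chloro-3-(trifluoromethyl)phenyl ring kept, restoring the amino link gives a 2.6-fold lower number from compound 2 to compound 3 (0.41 log units; beyond the scatter), whereas adding chloro in place of hydrogen on an aromatic carbon gives a 1.1-fold higher number from compound 1 to compound 3 (0.03 log units; within the scatter), so among these three compounds the difference follows the amino link and not the chloro. Nothing available explains why the amino link matters here.

From the compounds shown here alone, it remains open whether a methylene or an oxygen in place of the amino link would keep the number close to that of compound 3. Going by these compounds, it is equally open whether a methyl group on that nitrogen, replacing its hydrogen, would do so.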